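Moving the Methoxy Group: What to Expect for Compound 3

The source may report more compounds than this note shows. Statements on the series, on what has been measured and on what is new or still open speak of the compounds shown alone.

In a functional assay on HL-60 cells (Homo sapiens) for inhibition, read by CCK-8 assay, with a stated time of 48 h, tested at 20 uM (a lower number here means less inhibition of growth, a higher number more inhibition of growth at the concentration tested), compound 2 `COc1ccc(-c2nnc(NC(=O)/C(C#N)=C/c3cccc(OS(=O)(=O)c4ccc(C)cc4)c3)s2)cc1` gives 73%, the highest of the two numbers shown, though compound 1 `Cc1ccc(S(=O)(=O)Oc2cccc(/C=C(\C#N)C(=O)Nc3nnc(C)s3)c2)cc1` with 71% sits within the scatter of it, as a number 2 percentage points higher from compound 1 to compound 2 (within the scatter). Compound 3 `COc1ccccc1-c1nnc(NC(=O)/C(C#N)=C/c2cccc(OS(=O)(=O)c3ccc(C)cc3)c2)s1` has not been measured. It differs from compound 2 by 2-methoxyphenyl in place of 4-methoxyphenyl on an aromatic carbon. Within the data shown here, the single measured step swapped methyl for 4-methoxyphenyl and stayed within the scatter; no step that moves a group around that ring is available, so nothing beyond the scatter is expected. For compound 3 the expected step is a number 3 percentage points lower from compound 2 to compound 3 (within the scatter). Compound 3 is therefore estimated at 70%, between 55% and 85%.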

Compound 3, percent growth inhibition at one concentration: 73%
Compound 3: the middle estimate sits 3 percentage points below what was measured, within the range that was stated.
By their numbers in this assay, from the lowest: compounds 1, 2 and 3 (each within the scatter of the next).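

In this assay, moving the methoxy group around the phenyl ring, with 2-methoxyphenyl in place of 4-methoxyphenyl, gives no change at the digits printed from compound 2 to compound 3 (within the scatter) at this position on the core. Methyl gives way to 2-methoxyphenyl with a number 2 percentage points higher from compound 1 to compound 3 (within the scatter) as the result, so all three groups on this carbon read alike in this test. Nothing available gives a reason for this sameness. From the compounds shown here alone, whether an amine or a carboxylic acid on the phenyl ring, or a longer chain in place of methyl, would move the number stays open.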